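Cytotoxicity notes on three measured compounds and one pending

The source may report more compounds than this note shows. Statements on the series, on what has been measured and on what is new or still open speak of the compounds shown alone.

Compound 1, `Cc1cc(NC(=O)Nc2ccc(C(C)(C)C)cc2)c2ccccc2n1`: in an ADME assay on BJ cells (Homo sapiens) for cytotoxicity, with a stated time of 72 h (a lower number here means that less compound is needed, a higher number that more compound is needed for the effect), compound 1 gives 20000 nM.
Compound 2, `Cc1cc(NC(=O)Nc2ccc(Cl)cc2)c2ccccc2n1`: for compound 2 this assay returns only a limit, > 25000 nM.
Compound 3, `Cc1cc(NC(=O)Nc2cccc(Cl)c2)c2ccccc2n1`: for compound 3 this assay again returns only a limit, > 25000 nM.

Compound 2 and compound 1 differ by tert-butyl in place of chloro on an aromatic carbon. The step is an at least 1.2-fold lower number from compound 2 to compound 1 (0.09 log units; that floor lies within the scatter), and its floor rests on (the limit of > 25000 nM in this assay, at which 2 of the 3 values shown sit). Compound 2 and compound 3 share their atoms joined differently, (3-chlorophenyl in place of 4-chlorophenyl on an amide-type nitrogen); the step is a step that the two limits leave unreadable from compound 2 to compound 3, since both sit at the limit of > 25000 nM in this assay, at which 2 of the 3 values shown sit.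

Compound 4, `Cc1cc(NC(=O)Nc2cccc(C(C)(C)C)c2)c2ccccc2n1`, is not yet measured. It differs from compound 3 by tert-butyl in place of chloro on an aromatic carbon. This is the same kind of change as that from compound 2 to compound 1, but the place differs: para to a large group there, meta to a large group here. The expected step in this assay is an at least 1.1-fold lower number from compound 3 to compound 4 (0.05 log units; that floor lies within the scatter), resting on the floor of an at least 1.2-fold lower number from compound 2 to compound 1 (0.09 log units; that floor lies within the scatter) and on compound 3 sitting at the limit of > 25000 nM in this assay, at which 2 of the 3 values shown sit. For compound 4 the estimate in this assay is 22000 nM, between 9000 nM and 50000 nM.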

Compound 4, half-maximal effective concentration in the BJ assay: > 25000 nM
Compound 4: a limit, no number; the forecaster's own chance of this, stated with the estimate: 55%; at least 1.1-fold (0.05 log units) between middle value and limit.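

In the BJ assay compound 3 gives > 25000 nM, which is a limit and not a number. In the BJ assay compound 4 gives > 25000 nM, which is also a limit and not a number. No step between compound 3 and compound 4 can be read in the BJ assay: the limit of > 25000 nM in the BJ assay, at which 3 of the 4 values shown sit.

In a physicochemical assay for solubility, at pH 7.4 (on this read-out higher numbers stand for higher solubility and lower numbers for lower solubility), compound 3 gives 800 nM and compound 4 gives 34700 nM. In the physicochemical assay this is a 43-fold higher number from compound 3 to compound 4 (1.64 log units; beyond the scatter).

The compounds shown leave open whether tert-butyl in place of chloro, meta to a large group, changes the number in the BJ assay at all.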